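The source may report more compounds than this note shows. Statements on the series, on what has been measured and on what is new or still open speak of the compounds shown alone.

Working notes on the series. All three measured compounds share one core and differ only in the aryl group on a saturated chain carbon bound to a nitrogen on an aromatic ring and a saturated chain carbon. In an assay on CHO cells for displacement of a labelled ligand from C-X-C chemokine receptor type 1 (Homo sapiens) (on this read-out lower numbers stand for stronger inhibition and higher numbers for weaker inhibition), compound 1 `CC[C@@H](Nc1c(Nc2cccc(C(=O)N(C)C)c2O)c(=O)c1=O)c1ccc(C)s1` gives 146 nM. In this assay compound 2 `CC[C@@H](Nc1c(Nc2cccc(C(=O)N(C)C)c2O)c(=O)c1=O)c1sccc1C` gives 123 nM, and compound 3 `CCC(CC)c1coc([C@@H](CC)Nc2c(Nc3cccc(C(=O)N(C)C)c3O)c(=O)c2=O)c1` gives 30 nM. Compound 2 therefore stands second highest of the three numbers; the nearest number lies within the scatter, as shown by a 1.2-fold lower number from compound 1 to compound 2 (0.07 log units; within the scatter), while the furthest lies beyond it, as shown by a 4.1-fold lower number from compound 2 to compound 3 (0.61 log units; beyond the scatter).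

Compound 4 `CC[C@@H](Nc1c(Nc2cccc(C(=O)N(C)C)c2O)c(=O)c1=O)c1cc(C(C)(C)C)co1` is not yet measured. Its change from compound 2 is 4-(tert-butyl)furan-2-yl in place of 3-methylthiophen-2-yl on a saturated chain carbon bound to a nitrogen on an aromatic ring and a saturated chain carbon. Among the compounds with values here, two measured steps bear on it: a 4.1-fold lower number from compound 2 to compound 3 (0.61 log units; beyond the scatter) and a 4.9-fold lower number from compound 1 to compound 3 (0.69 log units; beyond the scatter), both of which exchange a methyl-substituted thiophen-2-yl for a furan-2-yl carrying a branched alkyl group at the same place, and both are modest steps to a lower number beyond the scatter. The 4-(tert-butyl)furan-2-yl that enters is close to the 4-(pentan-3-yl)furan-2-yl of compound 3, so a step of similar direction and size is expected in this assay, roughly a 3.1-fold lower number from compound 2 to compound 4 (0.49 log units; beyond the scatter). Compound 4 is estimated at 40 nM, with a range from 15 nM to 110 nM.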

Compound 4, inhibition constant: 10 nM
Beside the measured number, compound 4's estimate is 4.0-fold (0.60 log units) above it; the measured number lies below the stated range.
By their numbers in this assay, from the lowest: compound 4; then compound 3; then compounds 2 and 1 (each within the scatter of the next).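

In this assay, within the data shown here, the alkyl group on an aromatic carbon of the furan-2-yl matters in its own right: a 3.0-fold lower number from compound 3 to compound 4 (0.48 log units; beyond the scatter), so tert-butyl and pentan-3-yl are not interchangeable here, which the earlier compounds could not show. The exchange of a methyl-substituted thiophen-2-yl for a substituted furan-2-yl at this place also now reaches large steps, a 12-fold lower number from compound 2 to compound 4 (1.09 log units; beyond the scatter) and a 15-fold lower number from compound 1 to compound 4 (1.16 log units; beyond the scatter), where compound 3 had given only modest ones, and compound 4 holds the lowest number of the series. Nothing in hand speaks to why these groups differ at this position.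

Each step from a thiophen-2-yl to compound 4 changes the ring and the alkyl group together, and the compounds shown do not separate the two; a 4-(tert-butyl)thiophen-2-yl or an unsubstituted furan-2-yl at the same place would do so. From the compounds shown here alone, it also stays open how far the trend between pentan-3-yl and tert-butyl extends to other groups on that aromatic carbon, such as isopropyl, cyclopropyl or trifluoromethyl.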